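The source may report more compounds than this note shows. Statements on the series, on what has been measured and on what is new or still open speak of the compounds shown alone.

Measured compounds:
compound 1, `O=c1c(-c2nnc(-c3ccc(F)cc3)o2)c[nH]c2ncc(-c3cccnc3)cc12`, 19.7%
compound 2, `CS(=O)(=O)c1ccc(-c2cnc3[nH]cc(-c4nnc(-c5ccc(Cl)cc5)o4)c(=O)c3c2)cc1`, 17%
compound 3, `CS(=O)(=O)c1ccc(-c2cnc3[nH]cc(-c4nnc(-c5cccnc5)o4)c(=O)c3c2)cc1`, 14.7%

All three were tested in a functional assay on HCT-116 cells (Homo sapiens) for inhibition, read by MTT assay, with a stated time of 24 h, tested at 10 uM; a lower number here means less inhibition of growth, a higher number more inhibition of growth at the concentration tested. Compound 3 stands at the low end of the three numbers, but its gaps to compound 2 and to compound 1 both lie within the scatter, so the three cannot really be told apart. Compound 4, `CS(=O)(=O)c1ccc(-c2cnc3[nH]cc(-c4nnc(-c5ccc(F)cc5)o4)c(=O)c3c2)cc1`, is compound 3 with one change: 4-fluorophenyl in place of pyridin-3-yl on an aromatic carbon. Going by the values given here, the only measured step touching this group is a number 2.3 percentage points lower from compound 2 to compound 3 (within the scatter), which stayed within the scatter, and compound 1, which also carries a 4-fluorophenyl group, sits in the same range. No step beyond the scatter is therefore expected in this assay. Compound 4 is estimated at 17%, with a range from 8% to 27%, meaning an expected step of a number 2.3 percentage points higher from compound 3 to compound 4 (within the scatter).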

Compound 4, percent growth inhibition at one concentration: 18.7%
Compound 4: middle estimate off by 1.7 percentage points, on the low side, and the stated range covers the measured number.
By their numbers in this assay, from the lowest: compounds 3, 2, 4 and 1 (each within the scatter of the next).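

In this assay, the change on the five-membered ring with two nitrogens and one oxygen gives a number 4 percentage points higher from compound 3 to compound 4 (within the scatter), and fluoro in place of chloro gives a number 1.7 percentage points higher from compound 2 to compound 4 (within the scatter). Pyridin-3-yl, 4-fluorophenyl and 4-chlorophenyl therefore cannot be told apart at this position. On the shared core, 4-(methylsulfonyl)phenyl in place of pyridin-3-yl gives a number 1 percentage points lower from compound 1 to compound 4 (within the scatter), so that site also shows no step beyond the scatter.

As far as these compounds go, whether an amine or a carboxylic acid at the first position would give a step beyond the scatter remains open. No measured evidence bears on why these numbers lie so close.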